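Methylsulfanyl at the oxazole in a ketone series

The source may report more compounds than this note shows. Statements on the series, on what has been measured and on what is new or still open speak of the compounds shown alone.

Three ketones sharing one core have been measured in an assay on isolated protein for inhibition of Fatty-acid amide hydrolase 1 (Rattus norvegicus); on this read-out higher numbers stand for weaker inhibition and lower numbers for stronger inhibition. Compound 1 `O=C(CCCCCCc1ccccc1)c1nc(Br)co1` gives 3 nM. Compound 2 `O=C(CCCCCCc1ccccc1)c1nc(Cl)co1` gives 4 nM. Compound 3 `Cc1coc(C(=O)CCCCCCc2ccccc2)n1` gives 520 nM, the highest of the three numbers; its nearest neighbour is compound 2 and the furthest compound 1, both well beyond the scatter away.

The two halogen compounds sit close together: a 1.3-fold higher number from compound 1 to compound 2 (0.12 log units; within the scatter). Replacing either halogen by methyl is a large step: a 170-fold higher number from compound 1 to compound 3 (2.24 log units; beyond the scatter) and a 130-fold higher number from compound 2 to compound 3 (2.11 log units; beyond the scatter).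

Compound 4 `CSc1coc(C(=O)CCCCCCc2ccccc2)n1` differs from compound 3 in one place: methylsulfanyl in place of methyl on an aromatic carbon. Going by the values given here, no measured step covers methyl to methylsulfanyl, so the expectation rests only on what the three numbers show. Both measured steps onto compound 3 place the methyl compound far weaker than the two halogen compounds, and methylsulfanyl is neither of those groups. The estimate for compound 4 in this assay is therefore placed between the methyl and halogen results, with a wide range, as a 6.5-fold lower number from compound 3 to compound 4 (0.81 log units; beyond the scatter). Compound 4 is expected at 80 nM, within 15 nM to 400 nM.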

Compound 4, inhibition constant: 29 nM
Compound 4: middle estimate off by 2.8-fold (0.44 log units), on the high side; measured number inside the range.
By their numbers in this assay, from the lowest: compounds 1 and 2 (each within the scatter of the next); then compound 4; then compound 3.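

Working notes on the position on the aromatic carbon next to the ring nitrogen: in this assay, the change from methyl to methylsulfanyl is a large one, with an 18-fold lower number from compound 3 to compound 4 (1.25 log units; beyond the scatter) on this read-out, so the poor result for compound 3 does not extend to every non-halogen group here. The halogen compounds still give lower numbers, with a 7.3-fold higher number from compound 2 to compound 4 (0.86 log units; beyond the scatter) and a 9.7-fold higher number from compound 1 to compound 4 (0.99 log units; beyond the scatter) as modest steps beyond the scatter, which places compound 4 in a distinct middle position among the four groups seen at this site. The data at hand offer no explanation for this order of groups.

On these data alone, four groups at one position give an order but no rule, so it remains open where methoxy, ethylsulfanyl, methylsulfonyl, an amine or a nitrile would fall relative to methylsulfanyl and the halogens. As far as these compounds go, all four compounds also share the same ketone and phenyl-ended chain, so whether the methyl to methylsulfanyl step keeps its size with a shorter or longer chain, or with the ketone replaced by an alcohol, remains open too.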